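The compounds below may be only part of what the source reports. "The series", "measured", "known", "first", "only" and "open" are said of these compounds alone.

The series here consists of three close relatives built on a shared core. Compound 1 `COc1ccc(OC)c(-c2cc(-c3ccc(Cl)cc3)nn2-c2ccc(S(=O)(=O)NC(C)=O)cc2)c1` and compound 2 `NS(=O)(=O)c1ccc(-n2nc(-c3ccc(Cl)cc3)cc2-c2cc(O)ccc2O)cc1` have been measured; compound 3 `CC(=O)NS(=O)(=O)c1ccc(-n2nc(-c3ccc(Cl)cc3)cc2-c2cc(O)ccc2O)cc1` has not. In a functional assay on cells (Leukemia cell, Homo sapiens) for cytotoxicity, read by sulforhodamine B assay, with a stated time of 48 h (a higher number here means a weaker inhibitor of growth, a lower number a stronger inhibitor of growth), compound 1 gives 50100 nM. In this assay compound 2 gives 61400 nM. Of the two numbers shown, that of compound 2 is nominally the higher, yet its gap to compound 1 sits within the usual scatter of the method, so the two cannot be told apart on this evidence, and no step between them is drawn.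

Compound 3 differs from compound 2 in a single spot: acetyl in place of hydrogen on a sulfonamide nitrogen. For the measured compounds named here, no measured pair in this set isolates that change, so its effect must be judged without a precedent. Compound 1 already carries the acetylated sulfonamide and lands close to compound 2, which suggests the acetyl group on its own does not move the read-out far. The step from compound 2 to compound 3 is therefore expected to be small, a 1.1-fold lower number from compound 2 to compound 3 (0.05 log units; within the scatter), in no fixed direction beyond the scatter. Compound 3 is estimated at 55000 nM, within a range from 25000 nM to 120000 nM.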

Compound 3, concentration for total growth inhibition: 92600 nM
Beside the measured number, compound 3's estimate is 1.7-fold (0.23 log units) below it, within the range that was stated.
By their numbers in this assay, from the lowest: compounds 1, 2 and 3 (each within the scatter of the next).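

In this assay, acetyl in place of hydrogen on a sulfonamide nitrogen now has a direct reading, with a 1.5-fold higher number from compound 2 to compound 3 (0.18 log units; within the scatter) and so the two groups cannot be told apart at this position on the shared core. Compound 3 also gives a second single-place comparison, 2,5-dihydroxyphenyl in place of 2,5-dimethoxyphenyl on an aromatic carbon, with a 1.8-fold higher number from compound 1 to compound 3 (0.27 log units; within the scatter) and so this exchange cannot be resolved by this read-out either. No measurement is available that bears on either result.

The compounds shown leave open whether a propanoyl or benzoyl group on the sulfonamide nitrogen would give a number that stands clear of these three. On these data alone, they also leave open whether an amine or a fluorine in place of the hydroxyl groups of 2,5-dihydroxyphenyl would move the number beyond the scatter, so the sensitivity of either site to a larger change remains unknown.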